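Hydroxy on the phenyl of the three-carbon chain

The compounds below may be only part of what the source reports. "The series", "measured", "known", "first", "only" and "open" are said of these compounds alone.

Two compounds have numbers in an assay on CHO cells for displacement of a labelled ligand from adenosine receptor A1 (Homo sapiens), read by scintillation counting; a higher number here means a weaker inhibitor, a lower number a stronger inhibitor. Compound 1 `CCc1nc(N)c2nn(-c3ccccc3)cc2n1` gives 90 nM. Going by the values given here, compound 2 `Nc1nc(CCCc2ccccc2)nc2cn(-c3ccccc3)nc12` gives 5.31 nM, the lowest of the two numbers, and the step of a 17-fold lower number from compound 1 to compound 2 (1.23 log units; beyond the scatter) is the only measured step. Compound 3 `Nc1nc(CCCc2ccccc2O)nc2cn(-c3ccccc3)nc12` is not yet measured; it differs from compound 2 by hydroxy in place of hydrogen on an aromatic carbon, on an aromatic carbon of a six-membered aromatic ring of carbon only, ortho to a large group. Among the compounds with values here, no measured step touches that ring; the single step available, from compound 1 to compound 2, concerns the chain and the benzyl and does not tell how a hydroxy on the benzyl's ring would act. The expectation for compound 3 in this assay therefore rests on compound 2 alone, and the step of a 1.1-fold higher number from compound 2 to compound 3 (0.05 log units; within the scatter) is estimated as none beyond the scatter. Compound 3 is thus expected at 6 nM, with a range from 2 nM to 20 nM.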

Compound 3, inhibition constant: 0.54 nM
Compound 3: middle estimate off by 11-fold (1.05 log units), on the high side; measured number outside the range, below it.
By their numbers in this assay, from the lowest: compound 3; then compound 2; then compound 1.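

In this assay, going by these compounds alone, the phenyl ring at the end of the three-carbon chain responds to substitution: hydroxy in place of hydrogen on an aromatic carbon, ortho to a large group, gives a step beyond the scatter (a 9.8-fold lower number from compound 2 to compound 3 (0.99 log units; beyond the scatter)), the first measured change on that ring. Measured from the shorter chain, 2-hydroxybenzyl in place of hydrogen gives (a 170-fold lower number from compound 1 to compound 3 (2.22 log units; beyond the scatter)), which exceeds the step for benzyl alone (a 17-fold lower number from compound 1 to compound 2 (1.23 log units; beyond the scatter)), so the gain from the hydroxy adds to the gain from the benzyl in this series. No available evidence bears on the origin of the hydroxy step.

On these data alone, it remains open whether this step is specific to hydroxy or would also appear with a methoxy, an amine or a fluorine on the same carbon, and whether hydroxy on another carbon of the ring would give a similar number. Also open, as far as these compounds go, is whether the step carries over to a 2-hydroxyphenyl group on a shorter or longer chain, and how these changes would read at any other adenosine receptor.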